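Swapping Ethoxy for a Pyrrolidinylmethyl Group

The source may report more compounds than this note shows. Statements on the series, on what has been measured and on what is new or still open speak of the compounds shown alone.

Compound 1 `CCOC(=O)c1ccnc(-c2ccc(OCC)cc2)c1` gives 80000 nM in an assay on COS-7 cells for inhibition of patatin-like phospholipase domain-containing protein 2 (Mus musculus); on this read-out higher numbers stand for weaker inhibition and lower numbers for stronger inhibition.
Compound 2 `CCOC(=O)c1cccc(-c2ccc(OCC)cc2)c1` gives 50000 nM in this assay.
Compound 3 `CCOC(=O)c1ccc(-c2ccc(OCC)cc2)o1` gives 50000 nM in this assay.

Compound 2 and compound 3 show the same number at the digits shown, and the number for compound 1 is only slightly higher, a difference that stays within the usual scatter of such measurements. All three are weak inhibitors. Compound 4 `CCOC(=O)c1cccc(-c2ccc(CN3CCCC3)cc2)c1` differs from compound 2 by (pyrrolidin-1-yl)methyl in place of ethoxy on an aromatic carbon. For the measured compounds named here, no pair of measured compounds shows what such a change does, so the expectation rests on compound 2 alone. A modest downward step a 1.7-fold lower number from compound 2 to compound 4 (0.22 log units; within the scatter) is expected, not beyond the scatter with confidence. Compound 4 is therefore estimated at 30000 nM, with a range from 8000 nM to 100000 nM.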

Compound 4, half-maximal inhibitory concentration: > 200000 nM
Compound 4 was reported as a limit (the forecaster's own chance of this, stated with the estimate: 20%); middle value at least 6.6-fold (0.82 log units) from the limit.
By their numbers in this assay, from the lowest: compounds 2, 3 and 1 (each within the scatter of the next). At a limit, above all of these: compound 4.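

Compound 4 gives > 200000 nM in this assay, and this value is a limit of the assay, not a number. Putting (pyrrolidin-1-yl)methyl in place of ethoxy on this aromatic carbon gives an at least 4.0-fold higher number from compound 2 to compound 4 (0.60 log units; beyond the scatter). For the compounds shown here, the earlier compounds all carry ethoxy here, so this is the first sign that the group at this position matters for inhibition, and this change weakens it.

As far as these compounds go, how a carboxylic acid or a butoxy chain on this carbon would fare stays open. So does whether the same change would act alike on the cores of compound 1 and compound 3.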